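Swapping the Fluorophenyl Cap on a Styryl Sulfone

The source may hold more compounds than are shown below. What is called first, only, known or untested is meant among the compounds shown, and "the series" means these compounds.

Three close relatives built on one shared core have been measured so far. Compound 1 `O=S(=O)(/C=C/c1ccc(F)cc1)Cc1ccc(Nc2ncnc3ccccc23)cc1` gives 13000 nM in a functional assay on NCI-H520 cells (Homo sapiens) (on this read-out higher numbers stand for weaker inhibition of growth and lower numbers for stronger inhibition of growth), the lowest of the three numbers. Compound 2 `O=S(=O)(/C=C/c1ccc(Cl)c(Cl)c1)Cc1ccc(Nc2ncnc3ccccc23)cc1` gives 32000 nM in this assay, and compound 3 `O=S(=O)(/C=C/c1ccc(Cl)cc1)Cc1ccc(Nc2ncnc3ccccc23)cc1` gives 46000 nM in this assay. Both moves away from compound 1 are modest but real: a 2.5-fold higher number from compound 1 to compound 2 (0.39 log units; beyond the scatter), and a 3.5-fold higher number from compound 1 to compound 3 (0.55 log units; beyond the scatter). Between those two, a 1.4-fold higher number from compound 2 to compound 3 (0.16 log units; within the scatter), so they cannot be told apart.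

The new member, compound 4 `O=S(=O)(/C=C/c1ccc(C(F)(F)F)cc1F)Cc1ccc(Nc2ncnc3ccccc23)cc1`, alters compound 1 at the same spot: 2-fluoro-4-(trifluoromethyl)phenyl in place of 4-fluorophenyl on a double-bonded chain carbon bound to a double-bonded chain carbon. The two measured steps that bear on this each changed the halogen pattern on that phenyl ring, and each raised the number beyond the scatter, with the exchange of fluoro for chloro the closer guide. A trifluoromethyl group is bulkier than either halogen, so the same direction is expected, and the step from compound 1 to compound 4 is estimated as a 3.1-fold higher number from compound 1 to compound 4 (0.49 log units; beyond the scatter) in this assay. Compound 4 is therefore expected to give about 40000 nM in this assay, with a likely range from 15000 nM to 100000 nM.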

Compound 4, concentration for 50% growth inhibition: 100000 nM
Estimate against measurement, compound 4: 2.5-fold (0.40 log units) below; the measured number falls inside the stated range.
By their numbers in this assay, from the lowest: compound 1; then compounds 2 and 3 (each within the scatter of the next); then compound 4.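

In this assay the 2-fluoro-4-(trifluoromethyl)phenyl group gives the largest step yet seen at this position (a 7.7-fold higher number from compound 1 to compound 4 (0.89 log units; beyond the scatter)), and it also separates clearly from both chlorinated rings (a 2.2-fold higher number from compound 3 to compound 4 (0.34 log units; beyond the scatter); a 3.1-fold higher number from compound 2 to compound 4 (0.49 log units; beyond the scatter)). Compound 4 is therefore the weakest growth inhibitor of the four and compound 1 the strongest, so each replacement of the 4-fluorophenyl group shown here raises the number, with none going against that pattern. Nothing available accounts for this result.

Compound 4 carries both a fluoro and a trifluoromethyl group on its ring, so the share of each in the step cannot be separated without the 2-fluorophenyl and 4-(trifluoromethyl)phenyl relatives. On these data alone, it also stays open whether a ring bearing a methoxy group, an amine or a carboxylic acid at this position would give a lower number than compound 1 or continue the rise.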